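Working notes on compounds 1 to 4

This account rests on a few compounds, and the source may have more. Where it says the series, first, only, none or still open, it means among the compounds named here.

Measured so far, in a functional assay on CHO cells for inhibition of Orexin/Hypocretin receptor type 1 (Homo sapiens), read by FLIPR and calcium flux; a higher number here means a weaker inhibitor, a lower number a stronger inhibitor:
compound 1 `CCN(CC)C(=O)CN(c1cc(N(CC)CC)ccc1Cl)S(=O)(=O)c1ccc(OC)c(OC)c1` gives > 10000 nM, which is a limit of the assay.
compound 2 `CCN(CC)C(=O)CN(c1ccc(C)cc1)S(=O)(=O)c1cccc(C)c1` gives > 10000 nM, again a limit.
compound 3 `CCN(CC)C(=O)CN(c1ccc(C)cc1)S(=O)(=O)c1cccc(F)c1` gives > 10000 nM, also a limit.

Compound 3 thus stands at the limit of the assay rather than at a number. All three values sit at the limit of > 10000 nM in this assay, at which 3 of the 3 values shown sit. Going by the values given here, the only single-point step in hand, a step that the two limits leave unreadable from compound 2 to compound 3, cannot be read for size or direction. Compound 4 `CCN(CC)C(=O)CN(c1ccc(C)cc1)S(=O)(=O)c1ccccc1C` differs from compound 3 by 2-methylphenyl in place of 3-fluorophenyl on a sulfonyl sulfur. Among the compounds with values here, no measured step bears on this change, so no direction beyond the scatter can be set in this assay. The expected step from compound 3 is a step that the limit leaves unreadable from compound 3 to compound 4. Compound 4 is therefore estimated at 15000 nM, with a range from 4000 nM to 60000 nM, most likely reported as a limit again.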

Compound 4, half-maximal inhibitory concentration: > 10000 nM
Compound 4 was reported as a limit; the forecaster's own chance of this, stated with the estimate: 85%; the middle value is on the limit's open side.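

No step from compound 2 or compound 3 to compound 4 can be read, because each value is a limit: the limit of > 10000 nM in this assay, at which 4 of the 4 values shown sit.

The compounds shown leave open which change to the shared core, if any, would give a measurable value in this assay.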